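Adding a trifluoromethyl to an ethoxy chain

The compounds below may be only part of what the source reports. "The series", "measured", "known", "first", "only" and "open" are said of these compounds alone.

Of the compounds shown here, two with the same core have been measured so far in an ADME assay on LLC-PK1 cells (Sus scrofa) for permeability; on this read-out higher numbers stand for higher permeability and lower numbers for lower permeability. Compound 1 `C#CCOc1cnc(C(=O)Nc2cc(F)c(F)c([C@@]3(C)N=C(N)S[C@@]4(COC)C[C@H]43)c2)c(C)c1` gives 19 10^-6 cm/s, and compound 2 `CCOc1cnc(C(=O)Nc2cc(F)c(F)c([C@@]3(C)N=C(N)S[C@@]4(COC)C[C@H]43)c2)cn1` gives 25 10^-6 cm/s. These two numbers lie within the usual scatter of each other, so compound 2 stands level with compound 1.

The next compound, compound 3 `COC[C@]12C[C@H]1[C@@](C)(c1cc(NC(=O)c3cnc(OCCC(F)(F)F)cn3)cc(F)c1F)N=C(N)S2`, differs from compound 2 in one place: trifluoromethyl in place of hydrogen on a saturated chain carbon, two bonds along the chain from an oxygen on an aromatic ring. The same difference, cut one bond further out, reads ethoxy to 3,3,3-trifluoropropoxy.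

Going by the values given here, only one measured step is available as a guide: a 1.3-fold higher number from compound 1 to compound 2 (0.12 log units; within the scatter). That step exchanged a whole group on a carbonyl carbon and stayed within the scatter. Among the compounds with values here, it does not test a trifluoromethyl directly, so it offers only weak guidance, and no measured step shows which way this change should go. A small drift is therefore the most that can be expected, with no shift beyond the scatter in this assay. The expected step is a 1.3-fold lower number from compound 2 to compound 3 (0.10 log units; within the scatter).

Compound 3 is estimated at 20 10^-6 cm/s, with an expected range from 11 10^-6 cm/s to 34 10^-6 cm/s.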

Compound 3, apparent permeability: 23 10^-6 cm/s
Estimate against measurement, compound 3: 1.2-fold (0.06 log units) below, and the stated range covers the measured number.
By their numbers in this assay, from the lowest: compounds 1, 3 and 2 (each within the scatter of the next).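

Read in this assay, the step of a 1.1-fold lower number from compound 2 to compound 3 (0.04 log units; within the scatter) puts compound 2 and compound 3 level with each other, even though the change adds a trifluoromethyl of 4 heavy atoms. Going by these compounds alone, this is the first measured step to test a single saturated chain carbon, two bonds along the chain from an oxygen on an aromatic ring; the earlier step exchanged a whole group on a carbonyl carbon. At this position, then, going from ethoxy to 3,3,3-trifluoropropoxy leaves the number within the usual scatter, although this single pair cannot show a general rule, and no supporting measurement is available to explain the result.

The compounds shown leave open whether a longer chain, such as butoxy, or an amine or a carboxylic acid on the same chain carbon would also stay within the scatter. They also leave open whether the same trifluoromethyl exchange would give a similar step on another chain, such as the propargyloxy group of compound 1, or on a different part of the shared core.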